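The compounds below may be only part of what the source reports. "The series", "measured", "known", "first", "only" and "open" are said of these compounds alone.

In a functional assay on A549 cells (Homo sapiens) for inhibition, read by sulforhodamine B assay, with a stated time of 72 h (a lower number here means a stronger inhibitor, a higher number a weaker inhibitor), three amides of one shared core have been measured. Compound 1 `Nc1sc(-c2ccc(Cl)cc2)c(-c2ccc(Cl)cc2)c1C(=O)NC1CCC(O)CC1` gives 250 nM, compound 2 `Nc1sc(-c2ccc(Cl)cc2)c(-c2ccc(Cl)cc2)c1C(=O)N1CCC(=O)CC1=O` gives 4090 nM, and compound 3 `Nc1sc(-c2ccc(Cl)cc2)c(-c2ccc(Cl)cc2)c1C(=O)N1CCCC1` gives 890 nM, which places compound 3 in the middle of the three. Compound 4 `Nc1sc(-c2ccc(Cl)cc2)c(-c2ccc(Cl)cc2)c1C(=O)NCc1ccccc1` carries benzylamino in place of pyrrolidin-1-yl on a carbonyl carbon. For the measured compounds named here, no measured compound carries benzylamino, so the evidence is indirect. The closest guide is compound 1, which like compound 4 keeps the amide hydrogen, and the step of a 3.6-fold higher number from compound 1 to compound 3 (0.55 log units; beyond the scatter) is modest. The step of a 4.6-fold lower number from compound 2 to compound 3 (0.66 log units; beyond the scatter) is also modest, but compound 2 has no amide hydrogen and says less about this change. A modest move toward a lower number in this assay is therefore expected, with a result close to compound 3 still possible. The estimated step is a 2.0-fold lower number from compound 3 to compound 4 (0.30 log units; within the scatter). For compound 4 the expected value is 450 nM, with an estimated range of 130 nM to 1400 nM.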

Compound 4, half-maximal inhibitory concentration: 16300 nM
Estimate against measurement, compound 4: 36-fold (1.56 log units) below; measured number above the stated range.
By their numbers in this assay, from the lowest: compound 1; then compound 3; then compound 2; then compound 4.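

In this assay, for the compounds shown here, the amide substituent turns out to be able to cost far more than the earlier compounds showed: benzylamino in place of pyrrolidin-1-yl gives an 18-fold higher number from compound 3 to compound 4 (1.26 log units; beyond the scatter), and compound 4 is the weakest of the four, even against the 2,4-dioxopiperidin-1-yl amide, with a 4.0-fold higher number from compound 2 to compound 4 (0.60 log units; beyond the scatter). Keeping the amide hydrogen is therefore no guide on its own, since compound 1 and compound 4 both carry it, and benzyl in place of 4-hydroxycyclohexyl gives a 65-fold higher number from compound 1 to compound 4 (1.81 log units; beyond the scatter). As far as these compounds go, whether a cyclohexylamino amide, without the hydroxyl of compound 1, or a phenylamino amide would sit nearer compound 1 or compound 4 stays open. The data shown offer no measured account of why this change costs so much.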